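The compounds below may be only part of what the source reports. "The series", "measured", "known", "first", "only" and "open" are said of these compounds alone.

Of the compounds shown here, three have so far been measured in a functional assay on MDA-MB-231 cells (Homo sapiens) for cytotoxicity, read by MTT assay, with a stated time of 72 h; on this read-out higher numbers stand for weaker inhibition and lower numbers for stronger inhibition. Compound 3 `COc1cc2c(Oc3ccc(NC(=O)N/N=C/c4ccc(Cl)cc4Cl)cc3F)ccnc2cc1OCCCN1CCCCC1` gives 750 nM, the lowest of the three numbers. Compound 1 `COc1cc2c(Oc3ccc(NC(=O)N/N=C/c4ccc([N+](=O)[O-])cc4)cc3F)ccnc2cc1OCCCN1CCCC1` gives 970 nM, which sits within the scatter of compound 3, whereas compound 2 `COc1cc2c(Oc3ccc(NC(=O)N/N=C/c4ccc(C(F)(F)F)cc4)cc3F)ccnc2cc1OCCCN1CCCC1` gives 1800 nM, a gap beyond the scatter. Going by the values given here, the only single-point step measured, a 1.9-fold higher number from compound 1 to compound 2 (0.27 log units; within the scatter), concerns a different substituent on the same aryl tail, and both of those compounds differ from compound 3 in more than one place. Compound 4 `COc1cc2c(Oc3ccc(NC(=O)N/N=C/c4ccc(O)cc4)cc3F)ccnc2cc1OCCCN1CCCCC1` differs from compound 3 by 4-hydroxyphenyl in place of 2,4-dichlorophenyl on a carbon with a double bond to nitrogen. Among the compounds with values here, no measured step bears directly on this exchange, and the one step seen on that ring stayed within the scatter, so for compound 4 the expected step is a 2.0-fold higher number from compound 3 to compound 4 (0.30 log units; within the scatter). Compound 4 is therefore estimated at 1500 nM, in a range from 500 nM to 5000 nM.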

Compound 4, half-maximal inhibitory concentration: 790 nM
Beside the measured number, compound 4's estimate is 1.9-fold (0.28 log units) above it; low and high end bracket the measured number.
By their numbers in this assay, from the lowest: compounds 3, 4, 1 and 2 (each within the scatter of the next, the first and the last beyond it).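

In this assay, 4-hydroxyphenyl in place of 2,4-dichlorophenyl on the carbon with a double bond to nitrogen gives a small step (a 1.1-fold higher number from compound 3 to compound 4 (0.02 log units; within the scatter)). The earlier step only exchanged one group on the ring, whereas this one removes both chlorines and brings in a hydrogen-bond donor and acceptor, yet the numbers stay within the scatter of each other. No measurement shown here offers an explanation for this. As far as these compounds go, it remains open whether a ring carrying an amine or a carboxylic acid would fit as well. From the compounds shown here alone, a longer carbon chain in place of the ring is equally open.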